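Methoxy in place of chloro in compound 4

This account rests on a few compounds, and the source may have more. Where it says the series, first, only, none or still open, it means among the compounds named here.

Three compounds have been measured in an ADME assay on HEp-2 cells (Homo sapiens) for cytotoxicity; on this read-out lower numbers stand for higher toxicity in this test and higher numbers for lower toxicity in this test:
- Compound 1 `O=C(Nc1ccc(Cl)cc1Cl)[C@@H]1CCCN1S(=O)(=O)c1cccc2cccnc12` gives > 50000 nM (a limit)
- Compound 2 `Cc1ccc(C)c(NC(=O)[C@@H]2CCCN2S(=O)(=O)c2cccc3cccnc23)c1` gives 30900 nM
- Compound 3 `Cc1ccc(Cl)c(NC(=O)[C@@H]2CCCN2S(=O)(=O)c2cccc3cccnc23)c1` gives > 50000 nM (a limit)

The value for compound 3 is therefore a limit and not a number. Compound 3 stands at the limit of > 50000 nM in this assay, at which 2 of the 3 values shown sit, so the starting point of this step has no exact value.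

Compound 4 `COc1ccc(C)cc1NC(=O)[C@@H]1CCCN1S(=O)(=O)c1cccc2cccnc12` differs from compound 3 by methoxy in place of chloro on an aromatic carbon. The new methoxy sits on an aromatic carbon, ortho to a large group and para to a methyl group.

Methoxy itself has not been tested in this series, so the nearest guide is a different swap on an aromatic carbon. That swap is an at least 1.6-fold higher number from compound 2 to compound 3 (0.20 log units; that floor lies within the scatter), and its size is only a floor. A second step, an at least 1.6-fold lower number from compound 1 to compound 2 (0.20 log units; that floor lies within the scatter), is also a floor. The step that the two limits leave unreadable from compound 1 to compound 3 adds no size. None of these steps shows a change beyond the scatter, so no step beyond the scatter is expected in this assay, though a small move to a lower number is possible. The expected change is an at least 1.2-fold lower number from compound 3 to compound 4 (0.09 log units; that floor lies within the scatter). For compound 4 the estimate is 40000 nM, with an expected range from 18000 nM to 70000 nM.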

Compound 4, half-maximal cytotoxic concentration: > 50000 nM
Compound 4 ended at the assay's limit; the forecaster's own chance of this, stated with the estimate: 50%; middle value at least 1.2-fold (0.09 log units) away from the limit.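

In this assay compound 4 gives > 50000 nM, which is a limit of the assay and not a number. The one new step that can be read is an at least 1.6-fold higher number from compound 2 to compound 4 (0.20 log units; that floor lies within the scatter), so methoxy in place of methyl on this aromatic carbon, ortho to a large group and para to a methyl group, is not shown to move the read-out beyond the scatter. The steps to compound 4 from compound 1 and from compound 3 have limits at both ends and cannot be read, and with methoxy now added, most of the compounds shown sit at the same limit: the limit of > 50000 nM in this assay, at which 3 of the 4 values shown sit.

Going by these compounds, whether an amine or a carboxylic acid on this aromatic carbon would give a number short of the limit stays open. The compounds shown also do not tell how far past the limit compound 1, compound 3 and compound 4 lie, so methoxy and chloro at this place cannot be ordered against each other.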